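Two chlorines in place of a methyl on the benzamide ring

This account rests on a few compounds, and the source may have more. Where it says the series, first, only, none or still open, it means among the compounds named here.

Three compounds share one core. Compound 1 `O=C(/C=C/c1cccc(NC(=O)c2ccccc2Cl)c1)c1nc2ccccc2[nH]1` gives 4570 nM in a functional assay on MCF7 cells (Homo sapiens) for antiproliferative activity, read by MTT assay, with a stated time of 48 h; a higher number here means a weaker inhibitor, a lower number a stronger inhibitor. Compound 2 `O=C(Nc1cccc(/C=C/C(=O)c2nc3ccccc3[nH]2)c1)c1ccc(Br)cc1` gives 7000 nM in this assay, and compound 3 `Cc1ccc(C(=O)Nc2cccc(/C=C/C(=O)c3nc4ccccc4[nH]3)c2)cc1` gives 9690 nM in this assay. Compound 3 therefore holds the highest of the three numbers; its nearest neighbour is compound 2, and the step of a 1.4-fold higher number from compound 2 to compound 3 (0.14 log units; within the scatter) lies within the scatter, whereas a 2.1-fold higher number from compound 1 to compound 3 (0.33 log units; beyond the scatter) is a modest step beyond it.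

Compound 4 `O=C(Nc1cccc(/C=C/C(=O)c2nc3ccccc3[nH]2)c1)c1cc(Cl)cc(Cl)c1` has not yet been measured. It differs from compound 3 in one place: 3,5-dichlorophenyl in place of 4-methylphenyl on a carbonyl carbon. The measured steps that bear on this change are those in which one substituted phenyl replaced another on a carbonyl carbon: a 1.5-fold higher number from compound 1 to compound 2 (0.19 log units; within the scatter) and a 2.1-fold higher number from compound 1 to compound 3 (0.33 log units; beyond the scatter), together with a 1.4-fold higher number from compound 2 to compound 3 (0.14 log units; within the scatter). Within the data shown here, compound 1 gave a lower number than compound 3, while compound 2 and compound 3 lie within the scatter of each other, and none of the measured compounds carries two chlorines on that ring. On that basis a small move towards lower numbers is expected, a 1.5-fold lower number from compound 3 to compound 4 (0.17 log units; within the scatter), though a result within the scatter of compound 3 would not surprise. Compound 4 is therefore estimated at 6500 nM in this assay, with a range from 2800 nM to 15000 nM.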

Compound 4, half-maximal inhibitory concentration: > 100000 nM
Compound 4: only a limit was reported; the forecaster's own chance of this, stated with the estimate: 5%; at least 15-fold (1.18 log units) between middle value and limit.
By their numbers in this assay, from the lowest: compounds 1, 2 and 3 (each within the scatter of the next, the first and the last beyond it). At a limit, above all of these: compound 4.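

Compound 4 is reported in this assay only as a limit: the limit of > 100000 nM in this assay, at which 1 of the 4 values shown sits.

Read against that limit, the substituted phenyl on this carbonyl carbon proves far less forgiving than the earlier compounds suggested, for 2-chlorophenyl, 4-bromophenyl and 4-methylphenyl were separated by steps no larger than modest, whereas 3,5-dichlorophenyl gives an at least 10-fold higher number from compound 3 to compound 4 (1.01 log units; beyond the scatter), an at least 14-fold higher number from compound 2 to compound 4 (1.15 log units; beyond the scatter) and an at least 21-fold higher number from compound 1 to compound 4 (1.34 log units; beyond the scatter). The earlier compounds shown here gave no sign of this, and the new result shows that a change confined to the phenyl ring, with the amide-type nitrogen and the shared core untouched, is enough to produce a large step.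

The compounds shown leave open whether the step belongs to the presence of two chlorines on the ring or to where they sit, as compound 1 carries one chlorine and stays at the low end of the series. How an unsubstituted phenyl, a methoxy group, an amine or a carboxylic acid on that ring would read also remains open, and the data offer no explanation for the step.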